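Swapping Chlorines for Methoxy Groups on a Benzylamine Arm

The source may hold more compounds than are shown below. What is called first, only, known or untested is meant among the compounds shown, and "the series" means these compounds.

Measured compounds:
compound 1, `Nc1cc(N)c2nc(-c3ccccc3)c(NCc3ccc(Cl)c(Cl)c3)nc2c1`: 18600 nM
compound 2, `Nc1cc(N)c2nc(-c3ccccc3)c(Oc3ccc(F)cc3)nc2c1`: 19500 nM

In a functional assay on SK-MEL-28 cells (Homo sapiens) for inhibition, read by sulforhodamine B assay, with a stated time of 48 h (on this read-out lower numbers stand for stronger inhibition of growth and higher numbers for weaker inhibition of growth), compound 1 gives 18600 nM. Compound 2, which carries a different group on the shared core, gives 19500 nM in this assay, and the two numbers lie within the usual scatter of each other, so neither can be called stronger or weaker. Going by the values given here, no step between compounds differing in a single place is available, so there is no measured change to lean on.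

Compound 3, `COc1ccc(CNc2nc3cc(N)cc(N)c3nc2-c2ccccc2)cc1OC`, differs from compound 1 in one place: 3,4-dimethoxyphenyl in place of 3,4-dichlorophenyl on a saturated chain carbon bound to a nitrogen on an aromatic ring. Among the compounds with values here, nothing among the measured compounds shows how this kind of change shifts growth inhibition, so the expectation for the step from compound 1 to compound 3 is no change beyond the scatter, a 1.1-fold higher number from compound 1 to compound 3 (0.03 log units; within the scatter). Compound 3 is therefore estimated to give 20000 nM in this assay, with a range from 7000 nM to 60000 nM.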

Compound 3, concentration for 50% growth inhibition: 13500 nM
For compound 3 the middle estimate is 1.5-fold (0.17 log units) above the measured one; the measured number falls inside the stated range.
By their numbers in this assay, from the lowest: compounds 3, 1 and 2 (each within the scatter of the next).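

Going by these compounds alone, this is the first measured change at this position: in this assay, putting 3,4-dimethoxyphenyl in place of 3,4-dichlorophenyl on the saturated chain carbon gives a 1.4-fold lower number from compound 1 to compound 3 (0.14 log units; within the scatter). The two compounds therefore cannot be told apart on this read-out, even though the entering group has 2 hydrogen-bond acceptors and the leaving group has 0, and two oxygen-linked methyl groups replace two chlorines. No measurement shown here bears on why these two groups give numbers within the scatter of each other.

From the compounds shown here alone, whether a plain phenyl ring, or a ring carrying an amine or a carboxylic acid, would move the number beyond the scatter remains open. So does the effect of a longer chain in place of the single saturated carbon on this arm.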